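Hydrazide to tertiary amide on the shared core

The source may report more compounds than this note shows. Statements on the series, on what has been measured and on what is new or still open speak of the compounds shown alone.

Compound 1 `COc1cccc(-c2nc(SC)nc3sc(C(=O)NN)c(N)c23)c1` gives 8.5% in a functional assay on HEK293 cells for agonist activity at lutropin-choriogonadotropic hormone receptor (Homo sapiens), read by cAMP accumulation (a higher number here means a larger maximal response, a lower number a smaller maximal response), the lowest of the three numbers; compound 2 `COc1cccc(-c2nc(SC)nc3sc(C(=O)NC(C)(C)C)c(N)c23)c1F` gives 46.3% and compound 3 `CSc1nc(-c2cccc(O)c2)c2c(N)c(C(=O)NC(C)(C)C)sc2n1` gives 63.9%, both beyond the scatter above it. Compound 4 `COc1cccc(-c2nc(SC)nc3sc(C(=O)N(C)C(C)(C)C)c(N)c23)c1` differs from compound 1 by methyl(tert-butyl)amino in place of aminoamino on a carbonyl carbon. For the measured compounds named here, the one measured step, a number 17.6 percentage points higher from compound 2 to compound 3 (beyond the scatter), concerns the aromatic substituent and not the carbonyl side, so no step bears directly on this change. On these data alone, compounds 2 and 3 both carry a tert-butyl amide at this carbonyl and both sit well above compound 1, which favours an upward step; the added methyl on nitrogen is untested in this set. Compound 4 is expected to give 38% (range 8% to 68%), a step of a number 29.5 percentage points higher from compound 1 to compound 4 (beyond the scatter).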

Compound 4, largest response reached (reported as efficacy), in percent of the reference or control that the assay uses: 47.8%
Compound 4: the middle estimate sits 9.8 percentage points below what was measured; measured number inside the range.
By their numbers in this assay, from the lowest: compound 1; then compounds 2 and 4 (each within the scatter of the next); then compound 3.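

At the carbonyl carbon, the first step read at this position, methyl(tert-butyl)amino in place of aminoamino gives a number 39.3 percentage points higher from compound 1 to compound 4 (beyond the scatter) in this assay, a large change. The entering group has 0 hydrogen-bond donors against 2 for the group it replaces, so a sizeable response on this core does not depend on donors at this position. No measurement here explains the step.

On these data alone, the methyl and the tert-butyl enter together, so their separate shares remain unknown. As far as these compounds go, how a smaller dimethylamino or a cyclic morpholine would read at this carbonyl also stays open.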